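From Hydroxy to Methoxy on a Weak Inhibitor

The compounds below may be only part of what the source reports. "The series", "measured", "known", "first", "only" and "open" are said of these compounds alone.

Of the compounds shown here, two have so far been measured in a functional assay (QGY7701 cells, Homo sapiens) for inhibition, read by MTT assay, with a stated time of 48 h (a lower number here means a stronger inhibitor, a higher number a weaker inhibitor), as the test. Compound 1 (`COc1ccc2c(=O)c(/C=C/C(=O)Nc3cccc(C)c3)coc2c1`) is reported as > 100000 nM and this is a limit of the assay, not a number. Among the compounds with values here, compound 2 (`O=C(/C=C/c1coc2cc(O)ccc2c1=O)NCc1ccccc1`) gives 63000 nM as the only true number available, so it has no measured neighbour to be ranked against. Compound 3 (`COc1ccc2c(=O)c(/C=C/C(=O)NCc3ccccc3)coc2c1`) departs from compound 2 in one place: methyl in place of hydrogen on an oxygen on an aromatic ring with methyl in place of hydrogen on an oxygen on an aromatic ring, or hydroxy to methoxy. Within the data shown here, no measured pair shows what this change does in this assay on its own. A small shift towards weaker inhibition is expected, no larger than the usual scatter. The expected step is a 1.2-fold higher number from compound 2 to compound 3 (0.08 log units; within the scatter) in this estimate. For compound 3 the estimate is 75000 nM with an expected range from 30000 nM to 150000 nM as its ends.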

Compound 3, half-maximal inhibitory concentration: > 100000 nM
Compound 3: no number, only a limit; the forecaster's own chance of this, stated with the estimate: 40%; middle value at least 1.3-fold (0.12 log units) away from the limit.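

In this assay compound 3 gives > 100000 nM, which is a limit of the assay and not a number. Within the data shown here, the change from hydroxy to methoxy on the aromatic ring amounts to an at least 1.5-fold higher number from compound 2 to compound 3 (0.20 log units; that floor lies within the scatter), the first direct reading of this change; only a floor is known, so the true step may be larger or may stay within the scatter. The step between compound 1 and compound 3 cannot be read, and the limit restricts what these compounds can show: the limit of > 100000 nM in this assay, at which 2 of the 3 values shown sit.

On these data alone, it remains open whether the free hydroxy itself matters, or whether other groups on this oxygen, such as a longer ethyl chain or a chain ending in an amine, would give a true number. As far as these compounds go, it is also open how the hydroxy to methoxy change behaves with a different group on the amide nitrogen.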